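A few compounds are considered here, and "the series" means these few. Any claim that something is new, unique, unknown or untested is made for them only; others in the source may bear on it.

Measured in a functional assay on A549 cells (Homo sapiens) for antiproliferative activity, read by MTT assay, with a stated time of 48 h; on this read-out lower numbers stand for stronger inhibition and higher numbers for weaker inhibition:
- compound 1 `Cc1cc2nc(-c3cn(-c4ccccc4)nc3-c3ccccc3)[nH]c2cc1C`: 14500 nM
- compound 2 `Cc1cc2nc(-c3cn(-c4ccccc4)nc3-c3ccc(Cl)cc3)[nH]c2cc1C`: 17700 nM

Compound 2, at 17700 nM, has the higher of the two numbers in this assay, but its gap to compound 1 lies within the scatter, so the two stand level.

Compound 3 `COc1ccc(-c2nn(-c3ccccc3)cc2-c2nc3cc(C)c(C)cc3[nH]2)cc1` is still unmeasured. Its change from compound 2 is methoxy in place of chloro on an aromatic carbon, that is, 4-chlorophenyl to 4-methoxyphenyl, with methoxy in place of chloro on an aromatic carbon, para to a large group.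

For the measured compounds named here, the one measured step that bears on this is a 1.2-fold higher number from compound 1 to compound 2 (0.09 log units; within the scatter), with chloro in place of hydrogen on that same aromatic carbon. Going by the values given here, no methoxy compound has been measured, so the evidence is thin. No shift beyond the scatter is expected in this assay. The expected change is a 1.2-fold lower number from compound 2 to compound 3 (0.07 log units; within the scatter). For compound 3 the estimate is 15000 nM, with an expected range of 7500 nM to 30000 nM.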

Compound 3, half-maximal inhibitory concentration: 5850 nM
Compound 3: middle estimate off by 2.6-fold (0.41 log units), on the high side; the measured number lies below the stated range.
By their numbers in this assay, from the lowest: compound 3; then compounds 1 and 2 (each within the scatter of the next).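

In this assay this aromatic carbon, para to a large group, proves sensitive to what it carries: methoxy in place of chloro gives a 3.0-fold lower number from compound 2 to compound 3 (0.48 log units; beyond the scatter) and methoxy in place of hydrogen gives a 2.5-fold lower number from compound 1 to compound 3 (0.39 log units; beyond the scatter) so both steps are modest but beyond the scatter, unlike the earlier exchange of hydrogen for chloro. Of the three compounds, only compound 3 separates from the others, while compound 1 and compound 2 stand level, so the substituent at this carbon can matter even though chloro left the number unmoved. No measurement here accounts for methoxy parting from both chloro and hydrogen.

From the compounds shown here alone, whether the shift is particular to methoxy or also appears with ethoxy, hydroxy or dimethylamino at this carbon remains open. Also open, going by these compounds, is whether methoxy gives a similar step at other positions on the shared core.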